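The source may hold more compounds than are shown below. What is called first, only, known or untested is meant among the compounds shown, and "the series" means these compounds.

Measured so far in an ADME assay on HEK293 cells (Homo sapiens) for cytotoxicity, read by CCK-8 assay and cell counting, with a stated time of 2 days; a higher number here means a weaker inhibitor, a lower number a stronger inhibitor:

Compound 1 `Oc1ccc(-c2cc(-c3ccc(Cl)cc3)nc(-c3ccsc3)c2)cc1` gives 4860 nM.
Compound 2 `Oc1cccc(-c2cc(-c3ccc(Cl)cc3)nc(-c3ccsc3)c2)c1` gives 11200 nM.
Compound 3 `Oc1cccc(-c2cc(-c3ccccc3)nc(-c3ccc(Cl)cc3)c2)c1` gives 11600 nM.

Compound 4 `Oc1ccc(-c2cc(-c3ccccc3)nc(-c3ccc(Cl)cc3)c2)cc1` has not yet been measured in this assay.

Compound 3 differs from compound 2 in its core by phenyl in place of thiophen-3-yl on an aromatic carbon, and this step, a 1.0-fold higher number from compound 2 to compound 3 (0.02 log units; within the scatter), lies within the scatter, so the two cores give numbers that cannot be told apart here.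

Compound 4 is reached from compound 3 by 4-hydroxyphenyl in place of 3-hydroxyphenyl on an aromatic carbon. The same kind of change was made from compound 2 to compound 1, namely (4-hydroxyphenyl in place of 3-hydroxyphenyl on an aromatic carbon); the surroundings differ only in that the place is meta to a phenyl group in compound 3 and meta to a thiophen-3-yl group in compound 2. That earlier step was a 2.3-fold lower number from compound 2 to compound 1 (0.36 log units; beyond the scatter).

Since the two cores behave alike, the step from compound 3 to compound 4 in this assay is expected to be of similar size, about a 2.2-fold lower number from compound 3 to compound 4 (0.35 log units; beyond the scatter), resting on a 2.3-fold lower number from compound 2 to compound 1 (0.36 log units; beyond the scatter) and on the starting value of compound 3, 11600 nM. Compound 4 is therefore estimated at 5200 nM, most likely between 2800 nM and 9500 nM.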

Compound 4, half-maximal inhibitory concentration: 4810 nM
The estimate for compound 4 lay 1.1-fold (0.03 log units) above the measured number, and the stated range covers the measured number.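

In this assay, putting 4-hydroxyphenyl in place of 3-hydroxyphenyl gives a 2.4-fold lower number from compound 3 to compound 4 (0.38 log units; beyond the scatter), and this step matches the one seen earlier on the core with the thiophen-3-yl group: the same change on two cores in this assay, a 2.3-fold lower number (0.36 log units; beyond the scatter) from compound 2 to compound 1 and a 2.4-fold lower number (0.38 log units; beyond the scatter) from compound 3 to compound 4, 1.0-fold (0.02 log units) apart, within the scatter of two such steps

The other change, phenyl in place of thiophen-3-yl, gives a 1.0-fold lower number from compound 1 to compound 4 (0.00 log units; within the scatter), so it makes no visible difference with either hydroxyphenyl group: the same change on two cores in this assay, a 1.0-fold higher number (0.02 log units; within the scatter) from compound 2 to compound 3 and a 1.0-fold lower number (0.00 log units; within the scatter) from compound 1 to compound 4, 1.0-fold (0.02 log units) apart, within the scatter of two such steps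

Within these four compounds, then, the effect of the hydroxyl position carries from one core to the other, and each change can be read without knowing the other; this rests on only two closely related cores in a single cell assay, so it does not show that the step would hold on a more different core, and it says nothing about the reason for the step.

From the compounds shown here alone, whether an amine or a carboxylic acid in place of the hydroxyl group would give a similar number remains open. So does whether the same step would appear with a methyl group or a bare phenyl in place of the 4-chlorophenyl group.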